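This account rests on a few compounds, and the source may have more. Where it says the series, first, only, none or still open, it means among the compounds named here.

In an assay (strain Wistar) for inhibition of Amine oxidase [flavin-containing] A (Rattus norvegicus) (on this read-out lower numbers stand for stronger inhibition and higher numbers for weaker inhibition), compound 1 `NC(=O)[C@@H]1CCCN1Cc1cc(=O)oc2cc(OCc3ccccc3)ccc12` gives 35000 nM, the higher of the two numbers shown. Compound 3 `NNC(=O)Cc1cc(=O)oc2cc(OCc3cccc(Cl)c3)ccc12` gives 2500 nM in this assay, the lower of the two. Compound 2 `NC(=O)[C@@H]1CCCN1Cc1cc(=O)oc2cc(OCc3cccc(F)c3)ccc12` reaches only a limit of the assay, > 100000 nM in this assay. Within the data shown here, the single measured step between compounds that differ in one place, an at least 2.8-fold higher number from compound 1 to compound 2 (0.45 log units; beyond the scatter), ends at that limit (the limit of > 100000 nM in this assay, at which 1 of the 3 values shown sits), so its full size is not known. Compound 4 `CNCc1cc(=O)oc2cc(OCc3ccccc3)ccc12` differs from compound 1 by methylamino in place of 2-carbamoylpyrrolidin-1-yl on a saturated chain carbon bound to an aromatic carbon. Among the measured compounds shown here, no measured step bears directly on this kind of change: the only step alters an aromatic carbon and not the saturated chain carbon bound to an aromatic carbon, and compound 3 differs from compound 1 in two places at once, so its lower number cannot be assigned to either place. The expectation for compound 4 is therefore a number close to that of compound 1, with a wide range, a 1.4-fold lower number from compound 1 to compound 4 (0.15 log units; within the scatter). Compound 4 is estimated at 25000 nM, expected between 4000 nM and 100000 nM.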

Compound 4, half-maximal inhibitory concentration: 15400 nM
Estimate against measurement, compound 4: 1.6-fold (0.21 log units) above; low and high end bracket the measured number.
By their numbers in this assay, from the lowest: compound 3; then compound 4; then compound 1. At a limit, above all of these: compound 2.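

Among these compounds, changing the group on the saturated chain carbon bound to an aromatic carbon shifts the result in this assay, giving a 2.3-fold lower number from compound 1 to compound 4 (0.36 log units; beyond the scatter), the first measured step at this place. The 2-carbamoylpyrrolidin-1-yl group, with its ring and defined stereocentre, is therefore not required for the inhibition seen with compound 1, since the much smaller methylamino group gives a modestly lower number. Nothing shown here explains this step.

Going by these compounds, this single change removes the ring, the carbamoyl group and the stereocentre together, so the contribution of each part remains unknown. On these data alone, it also remains open whether a primary amine, a dimethylamino group or a longer chain on the amine nitrogen at this place would give a lower or a higher number than methylamino.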